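A Methyl for a Chloro: Expected Cytotoxicity of Compound 4

This account rests on a few compounds, and the source may have more. Where it says the series, first, only, none or still open, it means among the compounds named here.

Compound 1, with the structure `COC(=O)c1ccc(NCc2cncn2Cc2ccccc2Cl)cc1-c1ccccc1`, is the only one of the three measured compounds to give an actual number in a toxicity assay on NIH3T3 cells (Mus musculus) for cytotoxicity, read by resazurin assay; on this read-out higher numbers stand for an effect only at larger amounts of compound and lower numbers for an effect already at smaller amounts; in that assay compound 1 gives 10000 nM. Compound 2, `Cc1ccccc1-c1cc(NCc2cncn2Cc2ccc(-c3ccccc3)cc2)ccc1-c1nc2ccccc2s1`, reaches only a limit of the assay in this assay, reported as > 1000 nM. Compound 3, `c1ccc(-c2ccc(Cn3cncc3CNc3ccc(N4CCCCC4)c(-c4ccccc4)c3)cc2)cc1`, likewise stops at a limit of the assay, reported as > 1000 nM. So the single number shown stands alone against two limits, and the limit of > 1000 nM in this assay, at which 2 of the 3 values shown sit, describes where those two values sit.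

Compound 4, `COC(=O)c1ccc(NCc2cncn2Cc2ccccc2C)cc1-c1ccccc1`, has not yet been measured. It differs from compound 1 in one place: methyl in place of chloro on an aromatic carbon. Among the measured compounds shown here, no pair of measured compounds differs in a single place, so no measured step sets a scale for this exchange, and nothing in the data points to either direction. The step from compound 1 to compound 4 in this assay is therefore expected to stay within the scatter of repeated measurements, as no change at the digits printed from compound 1 to compound 4 (within the scatter) expresses. Compound 4 is accordingly estimated at 10000 nM in this assay, with an expected range from 3000 nM to 30000 nM, and a real chance remains that the assay reports only a limit rather than a number.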

Compound 4, half-maximal effective concentration: 10000 nM
For compound 4 middle estimate and measured number coincide at the digits printed, within the range that was stated.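

In this assay, among the compounds shown here, the step with methyl in place of chloro reads no change at the digits printed from compound 1 to compound 4 (within the scatter), and it is the first measured step in this set that changes a single place. At this position, on a six-membered aromatic ring of carbon only and ortho to a large group, the read-out therefore does not separate the 2-chlorobenzyl group from the 2-methylbenzyl group, two groups that differ by one heavy atom and that carry no hydrogen-bond donors or acceptors. Nothing among the measurements shown explains why the two groups give the same reading.

A single exchange says little about how much this position tolerates, so the compounds shown leave open whether an amine, a carboxylic acid or a longer chain at the same place would shift the value in this assay beyond the scatter. They also leave open whether methyl in place of chloro would read the same at another place on the ring or on a core other than that of compound 1.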